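Swapping the Aryl Group on the Triazole of Compound 3

The compounds below may be only part of what the source reports. "The series", "measured", "known", "first", "only" and "open" are said of these compounds alone.

Three compounds have so far been measured in a functional assay on DU-145 cells (Homo sapiens) for inhibition, read by MTT assay, with a stated time of 24 h; a lower number here means a stronger inhibitor, a higher number a weaker inhibitor:

Compound 1, `CCOC(=O)C1=Cc2ccccc2OC1(OCc1cn(CC(=O)Nc2ccc(OC)cc2)nn1)C(F)(F)F`: 32700 nM
Compound 2, `CCOC(=O)C1=Cc2ccccc2OC1(OCc1cn(-c2ccc(F)c([N+](=O)[O-])c2)nn1)C(F)(F)F`: 13200 nM
Compound 3, `CCOC(=O)C1=Cc2ccccc2OC1(OCc1cn(-c2ccc(F)c(Cl)c2)nn1)C(F)(F)F`: 21500 nM

Compound 3 stands second highest of these three numbers, and neither neighbour is clearly apart from it: the step of a 1.5-fold lower number from compound 1 to compound 3 (0.18 log units; within the scatter) and the step of a 1.6-fold higher number from compound 2 to compound 3 (0.21 log units; within the scatter) both stay within the scatter. Going by the values given here, only the step of a 2.5-fold lower number from compound 1 to compound 2 (0.39 log units; beyond the scatter) reaches beyond it, and even that is modest.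

Compound 4, `CCOC(=O)C1=Cc2ccccc2OC1(OCc1cn(-c2ccc([N+](=O)[O-])cc2)nn1)C(F)(F)F`, has not yet been measured in this assay. It differs from compound 3 in one place: 4-nitrophenyl in place of 3-chloro-4-fluorophenyl on an aromatic nitrogen. The nearest guide is compound 2, which also carries a nitro group on its aryl ring and sits at 13200 nM, while the change of chloro for nitro seen in a 1.6-fold higher number from compound 2 to compound 3 (0.21 log units; within the scatter) moved the number only within the scatter. On that basis the expected step of a 1.4-fold lower number from compound 3 to compound 4 (0.16 log units; within the scatter) is small and most likely toward a slightly lower number, not clearly beyond the scatter. The estimate for compound 4 in this assay is therefore 15000 nM, with a range from 6000 nM to 40000 nM.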

Compound 4, half-maximal inhibitory concentration: > 150000 nM
Compound 4 ended at the assay's limit; the forecaster's own chance of this, stated with the estimate: 10%; at least 10-fold (1.00 log units) between middle value and limit.
By their numbers in this assay, from the lowest: compounds 2, 3 and 1 (each within the scatter of the next, the first and the last beyond it). At a limit, above all of these: compound 4.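

In this assay, compound 4 gives no number, only a limit of the assay: the limit of > 150000 nM in this assay, at which 1 of the 4 values shown sits. Changes on this aromatic nitrogen had so far shifted the number modestly at most, but this swap of aryl groups gives the clearest steps in the series: an at least 6.9-fold higher number from compound 3 to compound 4 (0.84 log units; beyond the scatter), an at least 11-fold higher number from compound 2 to compound 4 (1.05 log units; beyond the scatter) and an at least 4.5-fold higher number from compound 1 to compound 4 (0.66 log units; beyond the scatter). The largest of these comes from the compound that also carries a nitro group, so among the compounds shown, a nitro group on the aryl ring does not by itself keep the number low: 4-fluoro-3-nitrophenyl and 4-nitrophenyl both have one, yet compound 2 and compound 4 end far apart.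

The 4-fluoro-3-nitrophenyl and 4-nitrophenyl groups differ both in the fluoro substituent and in where the nitro group sits, so the compounds shown cannot separate these two changes. Going by these compounds, a plain 3-nitrophenyl or 4-fluorophenyl group could help to do so, while a 4-aminophenyl group would show whether an amine in place of the nitro group changes the result, and the true value of compound 4 remains unknown.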